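Stripping the Acetoxy Group from Compound 1

This account rests on a few compounds, and the source may have more. Where it says the series, first, only, none or still open, it means among the compounds named here.

Within the data shown here, compound 1 `CCC[C@@H](OC(C)=O)C1=C(Br)C(=C(Br)Br)OC1=O` is the one compound of the three that gives a number in a functional assay on Lu1 cells (Homo sapiens) for cytotoxicity; a lower number here means that less compound is needed, a higher number that more compound is needed for the effect: compound 1 gives 1.1 ug/mL. The other two sit at the limit of > 20 ug/mL in this assay, at which 2 of the 3 values shown sit. Compound 2 `CCC[C@@H](OC(C)=O)C1=C(Br)[C@@](OC)(C(Br)Br)OC1=O` reaches only a limit, > 20 ug/mL, in this assay. Compound 3 `CCCCC1=C(Br)/C(=C/Br)OC1=O` likewise ends at a limit, > 20 ug/mL. Compound 4 `CCCCC1=C(Br)C(=C(Br)Br)OC1=O` has not yet been measured. It differs from compound 1 in one place: hydrogen in place of acetoxy on a saturated chain carbon bound to a double-bonded ring carbon and a saturated chain carbon. Among the measured compounds shown here, no step between measured compounds shows what this change does by itself. Compound 3 also carries hydrogen at that position and gives only a limit in this assay. The account therefore expects compound 4 to be weaker, a step of a 7.3-fold higher number from compound 1 to compound 4 (0.86 log units; beyond the scatter). Compound 4 is estimated at 8 ug/mL, within 2 ug/mL to 20 ug/mL.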

Compound 4, concentration for half-maximal effect: > 10.3 ug/mL
Compound 4: a limit, no number; the forecaster's own chance of this, stated with the estimate: 35%; middle value at least 1.2-fold (0.10 log units) away from the limit.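

In this assay, among these compounds, the single change from acetoxy to hydrogen brings an at least 9.3-fold higher number from compound 1 to compound 4 (0.97 log units; beyond the scatter). Among the compounds shown here, this is the first reading of that change on its own, and it shows that losing acetoxy from this saturated chain carbon is enough to lose the measurable number of compound 1. The value of compound 4 is a limit, so the full size of the step stays unknown: the limit of > 10.3 ug/mL in this assay, at which 1 of the 4 values shown sits.

Going by these compounds, whether a hydroxyl or a benzoyloxy group on this carbon would keep the number of compound 1 stays open. So does the effect of a longer chain alongside the acetoxy group.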